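The source may hold more compounds than are shown below. What is called first, only, known or untested is meant among the compounds shown, and "the series" means these compounds.

Compound 1 (`Cc1cccc(-n2cc(-c3ccc(/C=C4\C(=O)Nc5ccccc54)cc3)nn2)c1`) gives 13700 nM in an ADME assay on HUVEC cells (Homo sapiens) for inhibition, read by CCK-8 assay, with a stated time of 24 h, in the presence of a further agent that is not named here; a lower number here means a stronger inhibitor, a higher number a weaker inhibitor
Compound 2 (`O=C1Nc2ccccc2/C1=C/c1ccc(-c2cn(-c3ccccc3F)nn2)cc1`) gives 19300 nM in this assay

Compound 2 stands within the scatter of compound 1, so the two cannot be told apart. Compound 3 (`O=C1Nc2ccccc2/C1=C/c1ccc(-c2cn(-c3cccc(F)c3)nn2)cc1`) differs from compound 2 by a single swap (3-fluorophenyl in place of 2-fluorophenyl on an aromatic nitrogen), 3-fluorophenyl in place of 2-fluorophenyl on an aromatic nitrogen. Among the measured compounds shown here, the one measured step at that place (a 1.4-fold higher number from compound 1 to compound 2 (0.15 log units; within the scatter)) stayed within the scatter, so no step beyond the scatter is expected in this assay here. The estimated change (a 1.2-fold lower number from compound 2 to compound 3 (0.08 log units; within the scatter)) is accordingly small. For compound 3 the expected value is 16000 nM with an estimated range from 8000 nM to 30000 nM in this assay.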

Compound 3, half-maximal inhibitory concentration: > 20000 nM
Compound 3 was reported as a limit; the forecaster's own chance of this, stated with the estimate: 5%; middle value at least 1.2-fold (0.09 log units) from the limit.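

With compound 3 this position reaches a limit of the assay rather than a number: the limit of > 20000 nM in this assay, at which 1 of the 3 values shown sits.

Setting 3-fluorophenyl in place of 2-fluorophenyl gives an at least 1.0-fold higher number from compound 2 to compound 3 (0.01 log units; that floor lies within the scatter), and the comparison with the methyl-bearing compound gives an at least 1.4-fold higher number from compound 1 to compound 3 (0.16 log units; that floor lies within the scatter). Both are only floors, so neither change shows a step beyond the scatter in this assay, yet neither fixes the size of a step.

On these data alone, how far compound 3 truly lies from compound 2 stays open. So does whether an amine or a carboxylic acid on this phenyl group would lower the number.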